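Solubility notes: oxanyl in place of hydroxyethylphenyl

A few compounds are considered here, and "the series" means these few. Any claim that something is new, unique, unknown or untested is made for them only; others in the source may bear on it.

Compound 1 `CNC(=O)c1cc(C(=O)NC2CC2)cn(Cc2cccc3[nH]c(C)nc23)c1=O` and compound 2 `CNC(=O)c1cc(C(=O)NC2CC2)cn(Cc2cccc([C@@H](C)O)c2)c1=O` share one core and differ only in the group on the saturated chain carbon bound to the aromatic nitrogen. In a physicochemical assay for solubility (on this read-out lower numbers stand for lower solubility and higher numbers for higher solubility), compound 1 gives >= 198 ug/mL, which is a limit of the assay and not a number. In this assay compound 2 gives >= 131 ug/mL, again a limit rather than a number. Among the compounds with values here, compound 2 thus stands at the limit of >= 131 ug/mL in this assay, at which 1 of the 2 values shown sits, while compound 1 stands at the limit of >= 198 ug/mL in this assay, at which 1 of the 2 values shown sits; the two values give no step that can be sized. Compound 3 `CNC(=O)c1cc(C(=O)NC2CC2)cn(CC2CCOCC2)c1=O` has not been measured. It differs from compound 2 in one place (oxan-4-yl in place of 3-(1-hydroxyethyl)phenyl on a saturated chain carbon bound to an aromatic nitrogen). Within the data shown here, no measured step between these compounds exists, so the expectation rests on compound 2 alone. The step is expected to be a step that the limit leaves unreadable from compound 2 to compound 3, nothing beyond the scatter, quite possibly with a limit reported once more. The estimate for compound 3 in this assay is 200 ug/mL, within 100 ug/mL to 400 ug/mL.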

Compound 3, solubility: >= 165 ug/mL
Compound 3 was reported as a limit (the forecaster's own chance of this, stated with the estimate: 70%); the middle value lies beyond the limit too.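

In this assay compound 3 gives >= 165 ug/mL, a limit and not a number. Within the data shown here, compound 2 also stands at a limit, so no step between compound 2 and compound 3 can be read. As far as these compounds go, whether oxan-4-yl in place of 3-(1-hydroxyethyl)phenyl changes solubility at all stays open.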